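The compounds below may be only part of what the source reports. "The series", "measured", "known", "first", "only" and "open" are said of these compounds alone.

Among the compounds with values here, in a functional assay on U-87MG ATCC cells for inhibition, with U-87 MG (Homo sapiens) as the target, read by sulforhodamine B assay, with a stated time of 72 h (on this read-out higher numbers stand for weaker inhibition of growth and lower numbers for stronger inhibition of growth), compound 1 `O=S(=O)(Nc1cc(-c2cnc3[nH]ncc3c2)cnc1Cl)c1ccccc1` gives 8940 nM, the only exact number so far. Compound 2 `O=S(=O)(Nc1cc(-c2cnc3[nH]cc(-c4ccccc4)c3c2)cnc1Cl)c1ccccc1` reads > 10000 nM, which is a limit of the assay and not a number. Compound 3 `O=S(=O)(Nc1cc(-c2cnc3[nH]nc(-c4ccncc4)c3c2)cnc1Cl)c1ccccc1` departs from compound 1 by a single change, pyridin-4-yl in place of hydrogen on an aromatic carbon. Within the data shown here, no measured step bears on this change, so only a moderate strengthening of growth inhibition is expected in this assay relative to compound 1 at 8940 nM. The expected move is a 2.2-fold lower number from compound 1 to compound 3 (0.35 log units; beyond the scatter). Compound 3 is estimated at 4000 nM, with an expected range of 700 nM to 10000 nM.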

Compound 3, concentration for 50% growth inhibition: 3120 nM
Beside the measured number, compound 3's estimate is 1.3-fold (0.11 log units) above it; low and high end bracket the measured number.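

Placing pyridin-4-yl on this aromatic carbon of the five-membered aromatic ring, next to the ring nitrogen, gives the first reading of a change at this position in this assay: a 2.9-fold lower number from compound 1 to compound 3 (0.46 log units; beyond the scatter). The position therefore accepts a six-membered aromatic ring with a modest gain in growth inhibition, not a loss. Nothing shown explains this step.

On these data alone, it remains open whether a methyl group, an amine or piperidin-4-yl at this carbon would move the number in the same direction, and how much of the step depends on the pyridine nitrogen.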